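The compounds below may be only part of what the source reports. "The series", "measured", "known", "first", "only" and "open" are said of these compounds alone.

Compound 3 `COc1ncc(-c2ccc3ncc(NCC4CCCCC4)c(OC)c3c2)cc1NS(=O)(=O)c1ccc(F)cc1F` gives 13600 nM in a functional assay on HCT-116 cells (Homo sapiens) for antiproliferative activity, read by sulforhodamine B assay, with a stated time of 72 h (a higher number here means a weaker inhibitor, a lower number a stronger inhibitor), the second highest of the three numbers: compound 1 `COc1ncc(-c2ccc3ncc(NCc4ccccc4)c(OC)c3c2)cc1NS(=O)(=O)c1ccc(F)cc1F` gives 16800 nM, within the scatter of compound 3, while compound 2 `COc1ncc(-c2ccc3ncc(NC(=O)C4CCCCC4)c(OC)c3c2)cc1NS(=O)(=O)c1ccc(F)cc1F` gives 4610 nM, and a 3.0-fold higher number from compound 2 to compound 3 (0.47 log units; beyond the scatter) is beyond the scatter. Compound 4 `COc1ncc(-c2ccc3ncc(NC(=O)CN4CCN(C)CC4)c(OC)c3c2)cc1NS(=O)(=O)c1ccc(F)cc1F` differs from compound 3 by ((4-methylpiperazin-1-yl)methyl)carbonyl in place of cyclohexylmethyl on a nitrogen on an aromatic ring. For the measured compounds named here, two measured steps bear on this: a 3.0-fold higher number from compound 2 to compound 3 (0.47 log units; beyond the scatter) and a 3.6-fold lower number from compound 1 to compound 2 (0.56 log units; beyond the scatter), both modest, both favouring the carbonyl-bearing group on the aromatic nitrogen. Going by the values given here, the entering group carries a carbonyl, so a modestly lower number is expected, roughly a 2.7-fold lower number from compound 3 to compound 4 (0.43 log units; beyond the scatter), although the ring with two hetero atoms has no measured counterpart here. Compound 4 is therefore estimated at 5000 nM, with a range from 1500 nM to 16000 nM.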

Compound 4, half-maximal inhibitory concentration: 1540 nM
Compound 4: middle estimate off by 3.2-fold (0.51 log units), on the high side; the range from low to high includes it.
By their numbers in this assay, from the lowest: compound 4; then compound 2; then compounds 3 and 1 (each within the scatter of the next).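

In this assay the carbonyl alone does not set the level on this nitrogen on an aromatic ring: with the carbonyl kept, a 3.0-fold lower number from compound 2 to compound 4 (0.48 log units; beyond the scatter) comes with (4-methylpiperazin-1-yl)methyl in place of cyclohexyl. Against groups without a carbonyl the gap widens, with an 8.8-fold lower number from compound 3 to compound 4 (0.95 log units; beyond the scatter) and an 11-fold lower number from compound 1 to compound 4 (1.04 log units; beyond the scatter) for the whole change. So the group on the carbonyl carbon matters here as well, which the earlier compounds did not show.

From the compounds shown here alone, whether both ring nitrogens are needed stays open, and a morpholine or a dimethylamino group in place of the 4-methylpiperazine would test it. Nothing measured here explains the result.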